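From a 2-methoxyphenyl to a 1,3-thiazol-2-yl amide

The source may report more compounds than this note shows. Statements on the series, on what has been measured and on what is new or still open speak of the compounds shown alone.

Measured so far in a functional assay on HepG2 cells (Homo sapiens) for inhibition, read by MTT assay, with a stated time of 72 h; on this read-out higher numbers stand for weaker inhibition and lower numbers for stronger inhibition:
- compound 1 `CCCCc1ccc(NC(=O)C2CCN(C/C=C/c3ccccc3)CC2)cc1` gives 4320 nM
- compound 2 `COc1ccccc1NC(=O)C1CCN(C/C=C/c2ccccc2)CC1` gives 91200 nM
- compound 3 `CN1CCN(c2ccc(NC(=O)C3CCN(C/C=C/c4ccccc4)CC3)cc2)CC1` gives 35200 nM

Compound 2 has the highest number of the three and is therefore the weakest inhibitor here, with compound 3 nearest to it and compound 1 furthest away. Compound 4 `O=C(Nc1nccs1)C1CCN(C/C=C/c2ccccc2)CC1` has not yet been measured. It differs from compound 2 in one place, on an amide-type nitrogen, where 1,3-thiazol-2-yl stands in place of 2-methoxyphenyl (1,3-thiazol-2-yl in place of 2-methoxyphenyl on an amide-type nitrogen). Among the measured compounds shown here, no measured compound carries this new group, so the evidence is indirect. For the measured compounds named here, the only measured step, an 8.1-fold higher number from compound 1 to compound 3 (0.91 log units; beyond the scatter), is a modest one and involves a change on an aromatic carbon. With compound 2 at 91200 nM at the top of the measured range, a modest step towards a lower number is expected in this assay. The expected size is a 2.3-fold lower number from compound 2 to compound 4 (0.36 log units; beyond the scatter) and remains uncertain. For compound 4 the estimated value is 40000 nM, within an expected range of 12000 nM to 130000 nM.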

Compound 4, half-maximal inhibitory concentration: 22400 nM
Compound 4: middle estimate off by 1.8-fold (0.25 log units), on the high side; low and high end bracket the measured number.
By their numbers in this assay, from the lowest: compound 1; then compounds 4 and 3 (each within the scatter of the next); then compound 2.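

In this assay, among the compounds shown here, putting 1,3-thiazol-2-yl in place of 2-methoxyphenyl on the amide-type nitrogen gives a 4.1-fold lower number from compound 2 to compound 4 (0.61 log units; beyond the scatter), the first measured step at this position rather than on an aromatic carbon. It shows that the number responds to the group carried on this nitrogen, and that a six-membered aromatic ring of carbon only is not required there for a lower number. The change alters ring size, heavy-atom count and hetero atoms all at once, and no measurement bears on which of these matters.

From the compounds shown here alone, how a plain phenyl or a pyridin-2-yl group on the same nitrogen would compare remains open, and either could help separate the loss of the methoxy group from the change of ring. Going by these compounds, whether this step holds with other groups on the rest of the core also remains unknown.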